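This account rests on a few compounds, and the source may have more. Where it says the series, first, only, none or still open, it means among the compounds named here.

Series notes. In an assay on isolated protein for inhibition of ubiquitin carboxyl-terminal hydrolase 7 (Homo sapiens), with stated times of 30 min and 2 h (on this read-out higher numbers stand for weaker inhibition and lower numbers for stronger inhibition), compound 1 `Cn1cc(-c2ccc(CN3CCC(O)(Cn4cnc5c(-c6ccc(CN)cc6)n(C)nc5c4=O)CC3)c(Cl)c2)cn1` gives 291 nM, compound 2 `Cn1nc2c(=O)n(CC3(O)CCN(Cc4ccc(-c5ccoc5)cc4Cl)CC3)cnc2c1-c1ccc(CN)cc1` gives 177 nM and compound 3 `Cn1nc2c(=O)n(CC3(O)CCN(Cc4ccc(-c5ccsc5)cc4Cl)CC3)cnc2c1-c1ccc(CN)cc1` gives 59.5 nM, so compound 3 carries the lowest number of the three. The measured steps are a 1.6-fold lower number from compound 1 to compound 2 (0.22 log units; within the scatter), a 4.9-fold lower number from compound 1 to compound 3 (0.69 log units; beyond the scatter) and a 3.0-fold lower number from compound 2 to compound 3 (0.47 log units; beyond the scatter). Compound 4 `Cc1ccc(-c2ccc(CN3CCC(O)(Cn4cnc5c(-c6ccc(CN)cc6)n(C)nc5c4=O)CC3)c(Cl)c2)s1` differs from compound 3 by 5-methylthiophen-2-yl in place of thiophen-3-yl on an aromatic carbon. The closest comparison is the step from compound 2 to compound 3, which also exchanges one five-membered aromatic ring with one hetero atom for another on the same aromatic carbon. For the measured compounds named here, no measured step covers adding a methyl group to such a ring, so for compound 4 a shift no larger than the scatter is expected, and this assay is expected to give 60 nM (range 20 nM to 180 nM), that is a 1.0-fold higher number from compound 3 to compound 4 (0.00 log units; within the scatter).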

Compound 4, half-maximal inhibitory concentration: 101 nM
Estimate against measurement, compound 4: 1.7-fold (0.23 log units) below, within the range that was stated.
By their numbers in this assay, from the lowest: compounds 3, 4, 2 and 1 (each within the scatter of the next, the first and the last beyond it).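

With 5-methylthiophen-2-yl on the aromatic carbon para to a large group, the extra heavy atom and the changed ring attachment together give a 1.7-fold higher number from compound 3 to compound 4 (0.23 log units; within the scatter) and a 1.8-fold lower number from compound 2 to compound 4 (0.24 log units; within the scatter), so this ring stays level with both thiophen-3-yl and furan-3-yl in this assay. Against the pyrazole the picture differs, with a 2.9-fold lower number from compound 1 to compound 4 (0.46 log units; beyond the scatter), so a second sulfur-bearing ring also sits clear of 1-methyl-1H-pyrazol-4-yl. No measurement at hand accounts for these steps. Still open, from the compounds shown here alone, is whether the methyl group or the ring attachment matters here, which plain thiophen-2-yl would separate, and how an amine such as aminomethyl on the thiophene would read.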